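Ethoxy placed next to the amine: expected effect on ECa-109 inhibition

This account rests on a few compounds, and the source may have more. Where it says the series, first, only, none or still open, it means among the compounds named here.

Measured compounds:
compound 1 `O=C1C(Nc2ccccc2)=CC(=O)c2c1nc1n2[C@H]2OC[C@@H](O)[C@H]2OC1` gives 3560 nM
compound 2 `CCOc1ccc(NC2=CC(=O)c3nc4n(c3C2=O)[C@H]2OC[C@@H](O)[C@H]2OC4)cc1` gives 3210 nM
compound 3 `Cc1ccc(NC2=CC(=O)c3nc4n(c3C2=O)[C@H]2OC[C@@H](O)[C@H]2OC4)cc1C` gives 2820 nM

All three compounds share one core and differ only in the aryl group on the amine nitrogen. In a functional assay on ECa-109 cells for inhibition, with ECa-109 cell line (Homo sapiens) as the target, read by sulforhodamine B assay (on this read-out higher numbers stand for weaker inhibition and lower numbers for stronger inhibition), compound 1 has the highest of the three numbers, but the values of compound 1 and compound 2 lie within the scatter of each other, and compound 3 is also within the scatter of compound 1. Among the compounds with values here, the only single-point step between measured compounds, a 1.1-fold lower number from compound 2 to compound 3 (0.06 log units; within the scatter), likewise stays within the scatter, so no aryl substituent seen so far has moved this assay.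

Compound 4 `CCOc1ccccc1NC1=CC(=O)c2c(nc3n2[C@H]2OC[C@@H](O)[C@H]2OC3)C1=O` is compound 1 carrying the change (ethoxy in place of hydrogen on an aromatic carbon). Within the data shown here, no measured step covers exactly this ethoxy at this place; the closest evidence is that compound 2, which carries an ethoxy elsewhere on the same ring, gives 3210 nM while compound 1 gives 3560 nM, two numbers within the scatter. Compound 4 is therefore expected to show a 1.1-fold lower number from compound 1 to compound 4 (0.03 log units; within the scatter), a step of no consequence beyond the scatter. Compound 4 is estimated at 3300 nM, with a range from 1500 nM to 7500 nM.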

Compound 4, half-maximal inhibitory concentration: 4320 nM
The estimate for compound 4 lay 1.3-fold (0.12 log units) below the measured number; measured number inside the range.
By their numbers in this assay, from the lowest: compounds 3, 2, 1 and 4 (each within the scatter of the next).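

In this assay the change from phenyl to 2-ethoxyphenyl gives a 1.2-fold higher number from compound 1 to compound 4 (0.08 log units; within the scatter), so ethoxy on this aromatic carbon, ortho to a large group, does not separate compound 4 from compound 1. The earlier compounds shown here could speak to this position only indirectly, with ethoxy elsewhere on the ring in compound 2; this pair tests the position directly and shows that the ethoxy group can sit here with no change beyond the scatter, neither a gain nor a clear loss. Nothing available here offers an explanation for this result, so the pair records only what happens to the number and not why.

Within the data shown here, with ethoxy and methyl as the only groups on the ring across these four compounds, it remains open whether any substituent there can move the number beyond the scatter. As far as these compounds go, an amine or a carboxylic acid at this same place, or a longer chain in place of ethoxy, would put that question to a more demanding test, and the role of the shared core also remains open.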